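Amide substituent swap on the shared core

The source may report more compounds than this note shows. Statements on the series, on what has been measured and on what is new or still open speak of the compounds shown alone.

Measured in an assay on isolated protein for inhibition of Rho-associated protein kinase 2 (Homo sapiens), read by HTRF; a lower number here means a stronger inhibitor, a higher number a weaker inhibitor:
- compound 1 `O=C(c1ccc2c(c1)CC(c1nc3ccc(-c4cn[nH]c4)cc3c(=O)[nH]1)CO2)C1CC1`: 18 nM
- compound 2 `O=c1[nH]c(C2COc3ccc(F)cc3C2)nc2ccc(-c3cn[nH]c3)cc12`: 3 nM
- compound 3 `COCCNC(=O)c1ccc2c(c1)CC(c1nc3ccc(-c4cn[nH]c4)cc3c(=O)[nH]1)CO2`: < 1 nM

Compound 3 gives only a limit of this assay, not a number, and it sits at the limit of < 1 nM in this assay, at which 1 of the 3 values shown sits. Among the three measured compounds it carries the lowest number shown, with steps from both others beyond the scatter: an at least 18-fold lower number from compound 1 to compound 3 (1.25 log units; beyond the scatter) and an at least 3.0-fold lower number from compound 2 to compound 3 (0.47 log units; beyond the scatter).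

Compound 4 `O=C(NC1CC1)c1ccc2c(c1)CC(c1nc3ccc(-c4cn[nH]c4)cc3c(=O)[nH]1)CO2` is not yet measured. It differs from compound 3 by cyclopropyl in place of 2-methoxyethyl on an amide-type nitrogen. The amide itself is kept; only the substituent on its nitrogen changes. Among the compounds with values here, no measured step alters this position, so the bearing steps are indirect: the step from compound 1 to compound 3 exchanged a cyclopropyl ketone for the (2-methoxyethyl)amide and was large, while the step from compound 2 to compound 3 installed the whole carbamoyl group and was at least modest. Both point to the amide as the main contributor rather than to the 2-methoxyethyl chain. A small step is therefore expected in this assay, if any, and most likely toward a slightly higher number, an at least 1.5-fold higher number from compound 3 to compound 4 (0.17 log units; that floor lies within the scatter). For compound 4 the estimate is 1.5 nM, with a range from 0.5 nM to 5 nM.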

Compound 4, half-maximal inhibitory concentration: 1 nM
Estimate against measurement, compound 4: 1.5-fold (0.18 log units) above; the range from low to high includes it.
By their numbers in this assay, from the lowest: compound 4; then compound 2; then compound 1.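

In this assay, the amide carrying cyclopropyl in place of 2-methoxyethyl still gives an 18-fold lower number from compound 1 to compound 4 (1.26 log units; beyond the scatter), and likewise a 3.0-fold lower number from compound 2 to compound 4 (0.48 log units; beyond the scatter). The amide-type nitrogen therefore reaches a low number with a three-membered carbon ring that has no hydrogen-bond acceptor, so the acceptor of the 2-methoxyethyl chain is not required for a value at this level. The remaining step gives a number no lower from compound 3 to compound 4 (the limit leaves the size open). Its size cannot be read, because compound 3 carries only a limit of the assay, not a number: the limit of < 1 nM in this assay, at which 1 of the 4 values shown sits.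

Going by these compounds, how a 2-(dimethylamino)ethyl chain, a carboxylic acid on a longer chain or a larger carbon ring would read on this nitrogen stays open. Also open, on these data alone, is the effect of replacing the amide hydrogen with a methyl group.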